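The compounds below may be only part of what the source reports. "The series", "measured", "known", "first", "only" and "open" are said of these compounds alone.

Measured compounds:
compound 1 `c1ccc(-c2ccc3c(NCCCNCc4ccco4)ccnc3c2)cc1` — 9.47
compound 2 `COc1cccc(CNCCCNc2ccnc3cc(-c4ccccc4)ccc23)c1O` — 9.47
compound 3 `COc1ccc(F)cc1CNCCCNc1ccnc2cc(-c3ccc(F)cc3)ccc12` — 9.47

In a physicochemical assay for acid dissociation, compound 1 gives 9.47, level with compound 2 and compound 3 at the digits shown; the three values all lie within the scatter of one another, so no ordering among them can be drawn.

The compound not yet measured is compound 4 `COc1cccc(Oc2ccc3c(NCCCNCc4ccco4)ccnc3c2)c1`. It differs from compound 1 at the aromatic core: 3-methoxyphenoxy in place of phenyl on an aromatic carbon.

Among the compounds with values here, only one measured step bears on this. From compound 1 to compound 2 the change was at the saturated chain carbon bound to the amine nitrogen, and it gave no change at the digits printed from compound 1 to compound 2 (within the scatter). Within the data shown here, compound 3, which carries a para-fluorophenyl on the core together with a changed benzyl group, shows the same value as compound 1 and compound 2, though no single-place step connects it to either. Among the measured compounds shown here, no measured step alters the core aryl alone, so the change to compound 4 is untested. Given that the remote change from compound 1 to compound 2 left the value unmoved, the expectation for compound 4 is a step of no change at the digits printed from compound 1 to compound 4 (within the scatter), none beyond the scatter. Compound 4 is estimated at 9.47, range 9.1 to 9.8.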

Compound 4, acid dissociation constant: 9.28
Compound 4: the middle estimate sits 0.19 log units above what was measured; the measured number falls inside the stated range.
By their numbers in this assay, from the lowest: compounds 4, 1, 2 and 3 (each within the scatter of the next).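

In this assay, 3-methoxyphenoxy in place of phenyl on the aromatic carbon of the shared core gives a number 0.19 log units lower from compound 1 to compound 4 (within the scatter), so this change of the aryl group, with an added oxygen link and methoxy group, stays inside the scatter. Within the data shown here, it is the first reading of a change at this position alone, and it shows that this position tolerates the larger group without a step beyond the scatter. No measurement in hand speaks to why the reading falls where it does.

From the compounds shown here alone, whether a carboxylic acid or an amine on the aromatic carbon at this position would give a step beyond the scatter remains open. Also open, going by these compounds, is what a longer chain linking the two nitrogens of the side chain would do to the reading in this assay.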